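A few compounds are considered here, and "the series" means these few. Any claim that something is new, unique, unknown or untested is made for them only; others in the source may bear on it.

Compound 1, `CCc1ccc2nc(C(=O)Nc3c(F)cc(-c4cccc(F)c4)cc3F)c(C)c(O)c2c1`: 11.2%
Compound 2, `Cc1c(C(=O)Nc2c(F)cc(-c3cccc(F)c3)cc2F)nc2ccc(C(F)(F)F)cc2c1O`: 2.65%

Among the compounds with values here, in a functional assay on Hep 3B2 cells (Homo sapiens) for antiproliferative activity, read by MTT assay, with a stated time of 24 h, tested at 0.14 ug/mL (a higher number here means a stronger effect of the compound at the concentration tested, a lower number a weaker effect), compound 1 gives 11.2%, the higher of the two numbers measured so far. Compound 2 gives 2.65%, and the step of a number 8.6 percentage points lower from compound 1 to compound 2 (within the scatter) lies within the scatter, so the two compounds cannot be told apart on these numbers. Compound 3, `CCc1ccc2nc(C(=O)Nc3c(F)cc(-c4cccc(F)c4)cc3F)c(C)c(C(=O)O)c2c1`, has not yet been measured. It differs from compound 1 by carboxy in place of hydroxy on an aromatic carbon. Within the data shown here, the only measured step, a number 8.6 percentage points lower from compound 1 to compound 2 (within the scatter), concerns a trifluoromethyl in place of ethyl and leaves the hydroxy untouched, so no measured step bears directly on the change to compound 3. Among the measured compounds shown here, both numbers measured so far are small, and compound 3 is expected to remain at a similar level, with a number 2.2 percentage points lower from compound 1 to compound 3 (within the scatter) expected to fall within the scatter. The estimate for compound 3 in this assay is 9%, with a range from 0% to 25%.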

Compound 3, a percentage reported as inhibition, at one concentration (the size of the read-out at that concentration, not a potency): 0.68%
Estimate against measurement, compound 3: 8.3 percentage points above; the measured number falls inside the stated range.
By their numbers in this assay, from the lowest: compounds 3, 2 and 1 (each within the scatter of the next, the first and the last beyond it).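

This is the first change shown at the carbon opposite the ring nitrogen, and in this assay it produces a step that can be told apart from the scatter: a number 10.5 percentage points lower from compound 1 to compound 3 (beyond the scatter). The position therefore responds to what sits on it, at least when hydroxy gives way to carboxy, although the step is modest and rests on a single tested concentration. Nothing measured here gives a reason for this step.

The compounds shown leave open whether other groups at this position, such as an amine or a methyl ester, would stay at the level of compound 1 or that of compound 3. They also leave open whether the same exchange of hydroxy for carboxy would give a similar step with trifluoromethyl in place of ethyl, as in compound 2.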